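Replacing an aryl amide by a urea in the shared core

The source may hold more compounds than are shown below. What is called first, only, known or untested is meant among the compounds shown, and "the series" means these compounds.

For the measured compounds named here, compound 2 `CN(C(=O)c1ccc(Cl)cc1)c1ccc2[nH]c(-c3n[nH]c4ccccc34)cc2n1` gives 3.95 10^-6 cm/s in an ADME assay on MDCK cells (Canis lupus familiaris) for permeability, read by HPLC, in the apical to basolateral direction (on this read-out higher numbers stand for higher permeability and lower numbers for lower permeability), the highest of the two numbers measured, and its only neighbour, compound 1 `CN(C(=O)c1ccccc1)c1ccc2[nH]c(-c3n[nH]c4ccccc34)cc2n1`, gives 2.07 10^-6 cm/s. Going by the values given here, the one measured step is a 1.9-fold higher number from compound 1 to compound 2 (0.28 log units; within the scatter), so the chloro substituent brings no change that stands out from the scatter. Compound 3 `CN(C(=O)Nc1ccccc1)c1ccc2[nH]c(-c3n[nH]c4ccccc34)cc2n1` is the compound still to be measured. It differs from compound 2 by anilino in place of 4-chlorophenyl on a carbonyl carbon, which turns the benzamide into a phenylurea: the chlorine leaves and a nitrogen with one hydrogen-bond donor enters. Among the compounds with values here, the measured step of a 1.9-fold higher number from compound 1 to compound 2 (0.28 log units; within the scatter) bears on the loss of the chlorine and suggests that this part alone stays within the scatter, while no measured pair tells how the new donor on the carbonyl carbon acts in this assay. On balance a modest fall is expected, since a donor is added and a chlorine is removed relative to compound 2, yet the direction cannot be read from any measured pair. Compound 3 is therefore expected to give about 1.6 10^-6 cm/s, with a range from 0.6 10^-6 cm/s to 4.2 10^-6 cm/s, a step of a 2.5-fold lower number from compound 2 to compound 3 (0.39 log units; beyond the scatter).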

Compound 3, apparent permeability: 6.07 10^-6 cm/s
Beside the measured number, compound 3's estimate is 3.8-fold (0.58 log units) below it, and the stated range ends below it.
By their numbers in this assay, from the lowest: compounds 1, 2 and 3 (each within the scatter of the next, the first and the last beyond it).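

In this assay, anilino in place of 4-chlorophenyl on a carbonyl carbon gives a 1.5-fold higher number from compound 2 to compound 3 (0.19 log units; within the scatter), so at this position the urea, with the hydrogen-bond donor that the anilino group brings, cannot be told apart from the chlorinated benzamide. Set against the plain phenyl group, the same anilino group gives a 2.9-fold higher number from compound 1 to compound 3 (0.47 log units; beyond the scatter), and this modest step is the only one among these compounds to lie beyond the scatter, which makes it the first sign that the group on this carbonyl carbon can move the number at all. Nothing available here explains either step.

These compounds leave open whether the hydrogen on the urea nitrogen matters in itself, which a methyl group on that nitrogen would help to test against compound 3. They also leave open whether a chloro group on the anilino ring would add to the number, and whether a non-aromatic group on the carbonyl carbon, such as a piperidine or a morpholine, would fit the same trend.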